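The source may hold more compounds than are shown below. What is called first, only, known or untested is meant among the compounds shown, and "the series" means these compounds.

Working notes on the series. Compound 1 `COC(=O)[C@@]1(C)CC[C@@H]2C3=C1CC[C@@H](C)[C@]3(C)Cc1c2[nH]c2ccccc12` gives 3400 nM in a functional assay on T47D cells (Homo sapiens) for inhibition, read by sulforhodamine B assay, with a stated time of 48 h; on this read-out higher numbers stand for weaker inhibition of growth and lower numbers for stronger inhibition of growth. Going by the values given here, compound 2 `COC(=O)[C@@]1(C)CC[C@@H]2C3=C1CC[C@@H](C)[C@]3(C)Cc1c2[nH]c2ccc(C)cc12` gives 16000 nM in this assay, the highest of the two numbers so far; the one step measured in this part of the core, a 4.7-fold higher number from compound 1 to compound 2 (0.67 log units; beyond the scatter), shows that placing a substituent on this aromatic carbon weakened growth inhibition. Compound 3 `COC(=O)[C@@]1(C)CC[C@@H]2C3=C1CC[C@@H](C)[C@]3(C)Cc1c2[nH]c2ccc(Br)cc12` differs from compound 2 by bromo in place of methyl on an aromatic carbon. Among the compounds with values here, no measured step exchanges methyl for bromo, so the only bearing is indirect: the step from compound 1 to compound 2 says that a substituent here, of the size of a single heavy atom, costs potency against the unsubstituted core, and bromo is again a single heavy atom at that same place. On that basis a step of about a 1.2-fold lower number from compound 2 to compound 3 (0.09 log units; within the scatter) is expected, within the scatter rather than a clear move. Compound 3 is therefore estimated at 13000 nM in this assay, with a range of 4000 nM to 40000 nM.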

Compound 3, concentration for 50% growth inhibition: 21000 nM
The estimate for compound 3 lay 1.6-fold (0.21 log units) below the measured number; low and high end bracket the measured number.
By their numbers in this assay, from the lowest: compound 1; then compounds 2 and 3 (each within the scatter of the next).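

In this assay, bromo in place of methyl gives a 1.3-fold higher number from compound 2 to compound 3 (0.12 log units; within the scatter), so these two groups cannot be told apart at this aromatic carbon. Bromo in place of hydrogen gives a 6.2-fold higher number from compound 1 to compound 3 (0.79 log units; beyond the scatter), so the weaker growth inhibition seen with methyl is not confined to that one group. Both substituents, each of one heavy atom, give higher numbers than the unsubstituted core of compound 1, and neither of the substituted compounds shown goes against this.

Still open, on these data alone, is whether an amine, a carboxylic acid or a longer chain on this carbon would also weaken growth inhibition, and whether other carbons of this six-membered aromatic ring respond in the same way. No available evidence accounts for the loss seen with a substituent at this place.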